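A few compounds are considered here, and "the series" means these few. Any claim that something is new, unique, unknown or untested is made for them only; others in the source may bear on it.

In a functional assay on DU-145 cells (Homo sapiens) for cytotoxicity, read by XTT assay, with a stated time of 24 h (a lower number here means a stronger inhibitor, a higher number a weaker inhibitor), compound 1 `CC(=O)Oc1cc(OC(C)=O)c2c(OC(C)=O)cc(C)c(Cl)c2c1OC(C)=O` gives 59600 nM. Compound 2 `CC(=O)Oc1cc(OC(C)=O)c2c(OC(C)=O)c(C)cc(Cl)c2c1OC(C)=O`, which carries the same groups in a different arrangement, gives 81600 nM, and these two values lie within the scatter of each other. Compound 3 `Cc1cc(O)c2c(c1F)C(=O)C=CC2=O`, built quite differently, gives 15400 nM, a lower number than compound 1 by more than the scatter. Compound 1 therefore sits with compound 2 at the high end of this small set, where a high number means a weaker inhibitor.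

The next compound to consider is compound 4 `CC(=O)Oc1cc(OC(C)=O)c2c(OC(C)=O)cc(C)cc2c1OC(C)=O`, which keeps the core of compound 1 and makes one change: hydrogen in place of chloro on an aromatic carbon. In words, hydrogen takes the place of chloro on an aromatic carbon. Among the measured compounds shown here, no two measured compounds differ in just one place, so the data do not show directly what this swap does. The only clue is indirect: compound 2, at 81600 nM, stays within the scatter of compound 1 although its groups are arranged differently. A step beyond the scatter is therefore not expected in this assay, though the number may drift slightly upward. The estimate amounts to a 1.2-fold higher number from compound 1 to compound 4 (0.07 log units; within the scatter), an expected change within the scatter. For compound 4 the estimated value is 70000 nM, with an expected range from 30000 nM to 160000 nM.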

Compound 4, half-maximal inhibitory concentration: 64600 nM
Compound 4: middle estimate off by 1.1-fold (0.03 log units), on the high side; low and high end bracket the measured number.
By their numbers in this assay, from the lowest: compound 3; then compounds 1, 4 and 2 (each within the scatter of the next).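

Among the compounds shown here, this is the first comparison in the set that isolates a single change. In this assay, placing hydrogen where chloro stood, on the aromatic carbon ortho to a methyl group and para to an acetoxy group, gives a 1.1-fold higher number from compound 1 to compound 4 (0.03 log units; within the scatter). On the core of compound 1, then, this position can lose its chlorine without a change that can be told apart from ordinary repeat scatter, so the chloro group is not needed to hold the number at this level. No measurement bears on why the swap leaves the number where it is.

From the compounds shown here alone, with only chloro and hydrogen compared at this position, it remains open whether a different group there, such as an amine, a methoxy group or a carboxylic acid, would move the number beyond the scatter. Also open, going by these compounds, is whether hydrogen in place of chloro would behave in the same way in compound 2, whose groups are arranged differently, and what lies behind the lower number of compound 3, which differs from the others in more than one place.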